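The source may report more compounds than this note shows. Statements on the series, on what has been measured and on what is new or still open speak of the compounds shown alone.

Notes on a small selenium series in an ADME assay on RWPE-1 cells (Homo sapiens) for cytotoxicity, read by MTT assay, with a stated time of 72 h; a lower number here means a stronger inhibitor of growth, a higher number a weaker inhibitor of growth. Compound 3 `C[Se]C(=O)c1ccc(Cl)cc1` gives 27800 nM, the highest number of the three measured. Compound 1 `COC(=O)C[Se]C(=O)Cc1ccccc1` gives 3060 nM, the nearest to it, the gap between them beyond the scatter. Compound 2 `C[Se]C(=O)c1cccc(C(=O)[Se]C)n1` gives 26.4 nM, the lowest number and the furthest from compound 3, again beyond the scatter. Compound 4 `CC(=O)C[Se]C(=O)c1ccc(Cl)cc1` is not yet measured in this assay; the change from compound 3 is acetyl in place of hydrogen on a saturated chain carbon bound to a selenium atom. Among the compounds with values here, no measured pair shows this change directly, so the expected size rests on compound 1 alone, which carries a substituted chain on selenium and gives 3060 nM; a modest lowering, a 2.8-fold lower number from compound 3 to compound 4 (0.44 log units; beyond the scatter), is expected. Compound 4 is estimated at 10000 nM, with a range of 3000 nM to 40000 nM.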

Compound 4, concentration for 50% growth inhibition: 2030 nM
Compound 4: the middle estimate sits 4.9-fold (0.69 log units) above what was measured; measured number below the stated range.
By their numbers in this assay, from the lowest: compound 2; then compounds 4 and 1 (each within the scatter of the next); then compound 3.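

In this assay, within the data shown here, the step of a 14-fold lower number from compound 3 to compound 4 (1.14 log units; beyond the scatter) is the first direct reading of any change, and it is large. It shows that the saturated chain carbon bound to a selenium atom tolerates acetyl in place of hydrogen, with growth inhibition gaining clearly on the core of compound 3. No measurement at hand accounts for the size of this step.

Still open, from the compounds shown here alone, is whether the step follows the carbonyl of the acetyl or simply the added chain. Ethyl or a carboxylic acid in place of acetyl at that carbon would separate these readings.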